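Series notes: thiophene methylation step, compound 1 to compound 4

The source may hold more compounds than are shown below. What is called first, only, known or untested is meant among the compounds shown, and "the series" means these compounds.

Measured so far in an ADME assay on microsomes from liver (Rattus norvegicus) for metabolic stability; a lower number here means that the compound disappears faster, a higher number that the compound lasts longer:
- compound 1 `CC#C[C@@H](Cc1nnn[nH]1)c1ccc(OCc2ccc3scc(-c4ccc(OCCOC)cc4C)c3c2)cc1`: 0.217 h
- compound 2 `CC#C[C@@H](Cc1nnn[nH]1)c1ccc(OCc2ccc3scc(-c4ccc(OCCC(C)(C)O)cc4C)c3c2)cc1`: 1.03 h
- compound 3 `CC#C[C@@H](Cc1nnn[nH]1)c1ccc(OCc2ccc3scc(-c4cccnc4C)c3c2)cc1`: 0.183 h

Among these three numbers compound 1 holds the second highest. Its nearest neighbour is compound 3, with a 1.2-fold lower number from compound 1 to compound 3 (0.07 log units; within the scatter), a gap that lies within the scatter, so the two read as alike. The only clear separation is a 4.7-fold higher number from compound 1 to compound 2 (0.68 log units; beyond the scatter), a modest rise that comes with 1-hydroxy-1-methylethyl in place of methoxy on a saturated chain carbon, two bonds along the chain from an oxygen on an aromatic ring.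

Compound 4 `CC#C[C@@H](Cc1nnn[nH]1)c1ccc(OCc2ccc3sc(C)c(-c4ccc(OCCOC)cc4C)c3c2)cc1` differs from compound 1 by methyl in place of hydrogen on an aromatic carbon. The change sits on the five-membered aromatic ring with one sulfur, next to the ring sulfur and next to the ring atom that bears the 4-(2-methoxyethoxy)-2-methylphenyl group. Neither measured step touches that ring: one alters the side chain on the pendant aryl, the other exchanges the pendant aryl itself. For the measured compounds named here, no step in hand therefore bears directly on this change, and the expectation in this assay is no step beyond the scatter, in either direction.

On that basis compound 4 is estimated at 0.25 h, with a range of 0.1 h to 0.6 h. The expected step is a 1.2-fold higher number from compound 1 to compound 4 (0.06 log units; within the scatter).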

Compound 4, half-life: 0.117 h
Compound 4: middle estimate off by 2.1-fold (0.33 log units), on the high side, and the stated range covers the measured number.
By their numbers in this assay, from the lowest: compounds 4, 3 and 1 (each within the scatter of the next); then compound 2.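

In this assay, methyl in place of hydrogen on the aromatic carbon next to the ring sulfur gives a 1.9-fold lower number from compound 1 to compound 4 (0.27 log units; within the scatter) and, as a step within the scatter, leaves compound 4 reading as alike to compound 1. This is the only step shown on the five-membered aromatic ring with 1 sulfur, and this single added carbon opens no clear separation there, whereas a 4.7-fold higher number from compound 1 to compound 2 (0.68 log units; beyond the scatter) remains the only step beyond the scatter and lies in the side chain of the 4-(2-methoxyethoxy)-2-methylphenyl group. No measurement at hand speaks to what lies behind the size or direction of the step on this ring.

On these data alone, whether ethyl, a chlorine atom or hydroxymethyl on the same aromatic carbon would also read as alike to compound 1 remains open. Also open, as far as these compounds go, is whether methyl at this carbon would give a similar step on compound 2, which carries 1-hydroxy-1-methylethyl in place of methoxy, or on compound 3, which carries 2-methylpyridin-3-yl in place of 4-(2-methoxyethoxy)-2-methylphenyl.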